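The source may hold more compounds than are shown below. What is called first, only, known or untested is meant among the compounds shown, and "the series" means these compounds.

Compound 1 `Oc1cccc(Nc2nc(-c3cccc(F)c3)nc3ccc(F)cc23)c1` gives, in a functional assay on HL-60 cells (Homo sapiens) for cytotoxicity, read by MTT assay, with a stated time of 48 h (a lower number here means a stronger inhibitor, a higher number a weaker inhibitor), > 50000 nM, which is a limit of the assay and not a number.
Compound 2 `Nc1ccc(Nc2nc(-c3cccc(F)c3)nc3ccc(F)cc23)cc1` gives in this assay > 50000 nM, again a limit.
Compound 3 `Nc1cccc(Nc2nc(-c3cccc(F)c3)nc3ccc(F)cc23)c1` gives in this assay > 50000 nM, also a limit.

Compound 3 therefore stands at the edge of what this assay can report, with no number of its own, and the two companion values are limits as well, so nothing places it higher or lower than them. The three steps that connect the measured compounds, a step that the two limits leave unreadable from compound 1 to compound 2, a step that the two limits leave unreadable from compound 1 to compound 3 and a step that the two limits leave unreadable from compound 2 to compound 3, are all unreadable for the same reason: the limit of > 50000 nM in this assay, at which 3 of the 3 values shown sit. Compound 4 `Nc1ccccc1Nc1nc(-c2cccc(F)c2)nc2ccc(F)cc12` has not yet been measured. It differs from compound 3 by 2-aminophenyl in place of 3-aminophenyl on a nitrogen on an aromatic ring. Each rearrangement tried so far among the measured compounds, whether of the amino group or of the whole aryl ring on that nitrogen, left the value at the limit, so nothing seen here suggests that this further rearrangement would bring a readable number. For compound 4 the expectation in this assay is therefore 50000 nM, within 15000 nM to 50000 nM, most likely reported once more as a limit. The step this estimate implies, a number no higher from compound 3 to compound 4 (the limit leaves the size open), is expected to stay within the scatter.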

Compound 4, half-maximal inhibitory concentration: 41300 nM
Estimate against measurement, compound 4: 1.2-fold (0.08 log units) above; low and high end bracket the measured number.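

Swapping 3-aminophenyl for 2-aminophenyl gives the only true number in this set in this assay: compound 4 gives 41300 nM. Against the other three compounds, this reads as an at least 1.2-fold lower number from compound 3 to compound 4 (0.08 log units; that floor lies within the scatter), as an at least 1.2-fold lower number from compound 2 to compound 4 (0.08 log units; that floor lies within the scatter) and as an at least 1.2-fold lower number from compound 1 to compound 4 (0.08 log units; that floor lies within the scatter), so each comparison has a floor but no full size, and none of those floors shows a real difference. From the compounds shown here alone, the result shows that a (2-aminophenyl)amino group on the shared core can return a readable value, but the true size of each step stays open because the other compounds have only a limit: the limit of > 50000 nM in this assay, at which 3 of the 4 values shown sit.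

The steps among compound 1, compound 2 and compound 3 cannot be read at all. Going by these compounds, it remains open whether another group on this aryl ring, such as a carboxylic acid or a dimethylamino group, or a longer chain ending in an amine on that nitrogen, would give a value clearly separated from the limit.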